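Shortening the chain of compound 1 by one carbon

The source may hold more compounds than are shown below. What is called first, only, known or untested is meant among the compounds shown, and "the series" means these compounds.

Of the compounds shown here, three sharing one core have been measured in a functional assay on HEK293 cells for agonist activity at G-protein coupled receptor 84 (Homo sapiens), read by calcium flux; on this read-out higher numbers stand for an effect only at larger amounts of compound and lower numbers for an effect already at smaller amounts. Compound 1 `CCCCCCCCCc1nc(O)cc(O)n1` gives 48.7 nM in this assay. Compound 2 `CCCCCCCCNc1nc(O)cc(O)n1` gives 6.14 nM in this assay, and compound 3 `CCc1ccc(CCc2nc(O)cc(O)n2)cc1` gives 88.1 nM in this assay. Among these three, compound 1 stands second highest; the value of compound 3 lies nearest to it and within the scatter, whereas the value of compound 2 lies furthest from it, a lower number beyond the scatter.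

The step considered here leads from compound 1 to compound 4 `CCCCCCCCc1nc(O)cc(O)n1`, which has not yet been measured in this assay. The change is hydrogen in place of methyl on a saturated chain carbon, eight bonds along the chain from an aromatic carbon, so compound 4 carries a chain one carbon shorter than compound 1. Among the measured compounds shown here, no measured pair shows this kind of change, so its size must be estimated. The account expects the shorter chain to give a modestly higher number, a step that from compound 1 to compound 4 is estimated at a 2.0-fold higher number from compound 1 to compound 4 (0.29 log units; within the scatter), small enough that it might still fall within the scatter. For compound 4 in this assay the estimated value is 95 nM, with an expected range from 30 nM to 350 nM.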

Compound 4, half-maximal effective concentration: 11.4 nM
The estimate for compound 4 lay 8.3-fold (0.92 log units) above the measured number, outside the stated range (below it).
By their numbers in this assay, from the lowest: compounds 2 and 4 (each within the scatter of the next); then compounds 1 and 3 (each within the scatter of the next).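

In this assay, this position on the chain tolerates the loss of its methyl, and activity does not fall with the shorter chain: hydrogen in place of methyl on a saturated chain carbon, eight bonds along the chain from an aromatic carbon, gives a 4.3-fold lower number from compound 1 to compound 4 (0.63 log units; beyond the scatter) for this single change. Among the compounds shown here, the earlier compounds held no pair differing in one place, so this is the first measured sign that chain length alone can move the number beyond the scatter, and that a longer chain is not automatically the better one on this core. Compound 4 at 11.4 nM and compound 2 at 6.14 nM now lie within the scatter of each other, while the data shown offer no explanation for the size of the step.

One step cannot show whether the number keeps moving the same way with a still shorter chain such as heptyl or hexyl, or whether the octyl chain of compound 4 marks a turning point. Also open, on these data alone, is how the shared core would respond to a longer chain than that of compound 1, or to a carboxylic acid or an amine placed at the far end of the chain.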